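Swapping an aryl amide for an aryl sulfonamide on the core

The source may report more compounds than this note shows. Statements on the series, on what has been measured and on what is new or still open speak of the compounds shown alone.

Of the compounds shown here, three sharing one core have been measured in a functional assay on HL-60 cells (Homo sapiens) for antiproliferative activity, read by MTT assay, with a stated time of 72 h; on this read-out lower numbers stand for stronger inhibition and higher numbers for weaker inhibition. Compound 1 `CN(C(=O)CCc1ccccc1)c1ccc2[nH]c(-c3n[nH]c4ccccc34)cc2n1` carries a phenethyl group on its carbonyl carbon and gives 4730 nM. Compound 2 `CN(C(=O)c1ccc(Br)cc1)c1ccc2[nH]c(-c3n[nH]c4ccccc34)cc2n1` gives 1080 nM, and compound 3 `COc1cccc(C(=O)N(C)c2ccc3[nH]c(-c4n[nH]c5ccccc45)cc3n2)c1` gives 1420 nM. Compound 3 thus stands second highest of the three numbers: one step, a 1.3-fold higher number from compound 2 to compound 3 (0.12 log units; within the scatter), lies within the scatter, while the other, a 3.3-fold lower number from compound 1 to compound 3 (0.52 log units; beyond the scatter), lies beyond it.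

Compound 4 `CN(c1ccc2[nH]c(-c3n[nH]c4ccccc34)cc2n1)S(=O)(=O)c1ccccc1` has not yet been measured in this assay. The change from compound 3 is phenylsulfonyl in place of (3-methoxyphenyl)carbonyl on a nitrogen on an aromatic ring. Going by the values given here, the measured steps, a 4.4-fold lower number from compound 1 to compound 2 (0.64 log units; beyond the scatter) and a 3.3-fold lower number from compound 1 to compound 3 (0.52 log units; beyond the scatter), only compare aryl carbonyl groups with a phenethyl carbonyl; no measured step exchanges a carbonyl for a sulfonyl, so there is no direct precedent. The phenyl ring is retained, which argues for staying near compound 3. On that basis the step is expected to be a 1.4-fold higher number from compound 3 to compound 4 (0.15 log units; within the scatter), and compound 4 is estimated at 2000 nM, with a range from 700 nM to 6000 nM.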

Compound 4, half-maximal inhibitory concentration: 3700 nM
Estimate against measurement, compound 4: 1.9-fold (0.27 log units) below; low and high end bracket the measured number.
By their numbers in this assay, from the lowest: compounds 2 and 3 (each within the scatter of the next); then compounds 4 and 1 (each within the scatter of the next).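

In this assay this position responds to more than the presence of an aryl ring: the phenylsulfonyl group of compound 4 gives a 2.6-fold higher number from compound 3 to compound 4 (0.42 log units; beyond the scatter) and a 3.4-fold higher number from compound 2 to compound 4 (0.53 log units; beyond the scatter), so a six-membered aromatic ring alone does not keep the number near those of the two aryl carbonyl compounds. Compound 4 cannot be told apart from the phenethyl carbonyl compound, with a 1.3-fold lower number from compound 1 to compound 4 (0.11 log units; within the scatter), so two quite different groups on this nitrogen give numbers within the scatter of each other. Nothing available explains why the sulfonyl compound departs from the aryl carbonyl pair.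

This change also removes the methoxy group, so the part played by the sulfonyl cannot be separated from the loss of that methoxy. On these data alone, how a 3-methoxyphenylsulfonyl group or a plain benzoyl group would behave at this nitrogen remains open.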